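Nitro for methylsulfonyl, carried onto a second core

The source may report more compounds than this note shows. Statements on the series, on what has been measured and on what is new or still open speak of the compounds shown alone.

Compound 1 `CS(=O)(=O)c1ccc(C(=O)N2CCC(n3cncc3-c3ccc(OS(=O)(=O)c4cccc(C(=O)NC5CC5)c4)cc3)CC2)cc1` and compound 2 `O=C(NC1CC1)c1cccc(S(=O)(=O)Oc2ccc(-c3cncn3C3CCN(C(=O)c4ccc([N+](=O)[O-])cc4)CC3)cc2)c1` share one core; compound 3 `CS(=O)(=O)c1ccc(C(=O)N2CCN(c3cc(=O)[nH]c(=O)n3Cc3ccc(OS(=O)(=O)c4cccc5cnccc45)cc3)CC2)cc1` and compound 4 `O=C(c1ccc([N+](=O)[O-])cc1)N1CCN(c2cc(=O)[nH]c(=O)n2Cc2ccc(OS(=O)(=O)c3cccc4cnccc34)cc2)CC1` share another, and the difference between the two cores is not broken down here. In an assay on HEK293 cells for antagonist activity at P2X purinoceptor 7 (Homo sapiens), read by fluorescence, with a stated time of 2 h (a higher number here means a weaker inhibitor, a lower number a stronger inhibitor), compound 1 gives 400 nM, compound 2 gives 152 nM and compound 3 gives 44 nM. The change from compound 1 to compound 2 is nitro in place of methylsulfonyl on an aromatic carbon and gave a 2.6-fold lower number from compound 1 to compound 2 (0.42 log units; beyond the scatter). The change from compound 3 to compound 4 is nitro in place of methylsulfonyl on an aromatic carbon, the same change at the same kind of place. Compound 4 is not yet measured in this assay. Going by the values given here, the step is expected to be a 2.4-fold lower number from compound 3 to compound 4 (0.39 log units; beyond the scatter), sized to match the single comparable step because of a 2.6-fold lower number from compound 1 to compound 2 (0.42 log units; beyond the scatter) on the first core. Compound 4 is expected to give 18 nM in this assay, with a likely range from 7 nM to 50 nM.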

Compound 4, half-maximal inhibitory concentration: 27 nM
For compound 4 the middle estimate is 1.5-fold (0.18 log units) below the measured one; measured number inside the range.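

In this assay, nitro in place of methylsulfonyl gives a 1.6-fold lower number from compound 3 to compound 4 (0.21 log units; within the scatter), so on the core of compound 3 the change does not separate the two groups. Set beside the step on the core of compound 1, the size of the step does not differ measurably between the two cores: the same change on two cores in this assay, a 2.6-fold lower number (0.42 log units; beyond the scatter) from compound 1 to compound 2 and a 1.6-fold lower number (0.21 log units; within the scatter) from compound 3 to compound 4, 1.6-fold (0.21 log units) apart, within the scatter of two such steps. The change therefore carries across these two cores without a detectable difference in step size, but two pairs do not fix its size on any other core, and they do not explain the result.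

Open, as far as these compounds go, is how an amine or a carboxylic acid would compare with nitro on the same aromatic carbon, para to a large group. Also open, from the compounds shown here alone, is whether the step stays the same on a third core.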